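The compounds below may be only part of what the source reports. "The series", "measured", "known", "first", "only" and "open" are said of these compounds alone.

Compound 1 `C[C@@H]1CN(c2nc(-c3cnn(C)c3)ncc2C#N)CCN1C(=O)C1CC1` carries a cyclopropylcarbonyl on its saturated ring. In an ADME assay on microsomes from liver (Rattus norvegicus) for pharmacokinetics (a higher number here means faster removal of the compound, a lower number slower removal), compound 1 gives < 36 mL/min/kg, which is a limit of the assay rather than a number. Compound 2 `Cn1cc(-c2ncc(C#N)c(N3C[C@@H]4C[C@H]3CN4C(=O)C3CC3)n2)cn1` shares the same core and the same cyclopropylcarbonyl. In this assay compound 2 gives < 36 mL/min/kg, again a limit and not a number. Compound 1 therefore stands at the limit of < 36 mL/min/kg in this assay, at which 2 of the 2 values shown sit, and the numbers shown do not separate it from compound 2. Compound 3 `C[C@@H]1CN(c2nc(-c3cnn(C)c3)ncc2C#N)CCN1C(=O)C1(C)CC1` differs from compound 1 by methyl in place of hydrogen on a saturated ring carbon, that is, cyclopropylcarbonyl to (1-methylcyclopropyl)carbonyl. Among the measured compounds shown here, no measured pair speaks to this change, so the expected step is a step that the limit leaves unreadable from compound 1 to compound 3, a shift that would remain within the scatter. Compound 3 is accordingly estimated at about 25 mL/min/kg, in a range from 10 mL/min/kg to 50 mL/min/kg, quite possibly reported once more only as a limit.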

Compound 3, clearance: < 36 mL/min/kg
Compound 3: a limit, no number (the forecaster's own chance of this, stated with the estimate: 65%); the middle value lies beyond the limit too.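

No step from compound 1 to compound 3 can be read, as both stand only at a limit: the limit of < 36 mL/min/kg in this assay, at which 3 of the 3 values shown sit.

On these data alone, whether cyclopropylcarbonyl to (1-methylcyclopropyl)carbonyl changes clearance at all, and how compound 1, compound 2 and compound 3 order in this assay, stays open.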